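This account rests on a few compounds, and the source may have more. Where it says the series, first, only, none or still open, it means among the compounds named here.

Three compounds have been measured in an assay on BTI cells for inhibition of Amine oxidase [flavin-containing] B (Homo sapiens), read by fluorescence, with stated times of 30 min and 1 h, tested at 1 uM; a higher number here means more inhibition at the concentration tested (going by the name of the read-out), a lower number less inhibition:

compound 1 `C[C@H](NCc1ccc(OCCCCN2CCN(c3cccc4c3ccn4Cc3cccc(Cl)c3)CC2)cc1)C(N)=O`, 24%
compound 2 `C[C@H](NCc1ccc(OCCCCCCN2CCN(c3cccc4c3ccn4Cc3cccc(Cl)c3)CC2)cc1)C(N)=O`, 23%
compound 3 `C#CCN(C)Cc1ccc(OCCCCN2CCN(c3cccc4c3ccn4Cc3cccc(Cl)c3)CC2)cc1`, 85%

Compound 1 and compound 2 share most of their structure; how the two cores differ is not broken down here, and the values of compound 1 and compound 2 in this assay lie within the scatter of each other. Compound 3 differs from compound 1 in one place, (methyl(propargyl)amino in place of (1-carbamoylethyl)amino on a saturated chain carbon bound to an aromatic carbon), and this change made a number 61 percentage points higher from compound 1 to compound 3 (beyond the scatter). Compound 4 `C#CCN(C)Cc1ccc(OCCCCCCN2CCN(c3cccc4c3ccn4Cc3cccc(Cl)c3)CC2)cc1` has not yet been measured; it stands to compound 2 as compound 3 stands to compound 1, the change being (methyl(propargyl)amino in place of (1-carbamoylethyl)amino on a saturated chain carbon bound to an aromatic carbon), at the same place. Because compound 2 gives 23% in this assay, within the scatter of compound 1, the step is expected to repeat. Compound 4 is therefore expected to reach about 82%, estimated between 65% and 95%. The expected step is a number 59 percentage points higher from compound 2 to compound 4 (beyond the scatter), matching the earlier one.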

Compound 4, a percentage reported as inhibition, at one concentration (the size of the read-out at that concentration, not a potency): 32%
Compound 4: middle estimate off by 50 percentage points, on the high side; the whole stated range lies above it.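

On the core of compound 2, putting methyl(propargyl)amino in place of (1-carbamoylethyl)amino gave a number 9 percentage points higher from compound 2 to compound 4 (within the scatter) in this assay. The size of this change therefore depended on the core that carried it: the same change on two cores in this assay, a number 61 percentage points higher (beyond the scatter) from compound 1 to compound 3 and a number 9 percentage points higher (within the scatter) from compound 2 to compound 4, 52 percentage points apart, beyond the scatter of two such steps This rests on a single pair of cores and shows that the large step cannot be assumed to carry over, but it does not explain the difference or show how the change behaves on any other core.

The compounds shown leave open whether the large step would return with a shorter or a longer chain in the core. They also leave open how a dimethylamine or a plain propargylamine would behave in place of methyl(propargyl)amino.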